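Stereocentre inversion on the dihydroxypropyl arm of compound 1

The source may report more compounds than this note shows. Statements on the series, on what has been measured and on what is new or still open speak of the compounds shown alone.

The series shares the core of compound 1 `O=C1c2c[n+]([O-])c3ccccc3c2C(=O)c2c1c1ccccc1n2Cc1cn(C[C@H](O)CO)nn1`, which carries a 1-(2,3-dihydroxypropyl)-1H-1,2,3-triazol-4-yl group on the saturated chain carbon bound to the aromatic nitrogen. In a functional assay on SH-SY5Y cells (Homo sapiens) for cytotoxicity, read by MTT assay, with a stated time of 72 h (on this read-out lower numbers stand for stronger inhibition and higher numbers for weaker inhibition), compound 1 gives only a limit, > 1000 nM, and no number. Compound 2 `O=C1c2c[n+]([O-])c3ccccc3c2C(=O)c2c1c1ccccc1n2CCN1CCCCC1`, with (piperidin-1-yl)methyl in that place, gives 1860 nM in this assay. The step that the limit leaves unreadable from compound 1 to compound 2 cannot be read because of the limit of > 1000 nM in this assay, at which 1 of the 3 values shown sits. Compound 3 `O=C1c2c[n+]([O-])c3ccccc3c2C(=O)c2c1c1ccccc1n2Cc1cn([C@@H]2O[C@H](CO)[C@@H](O)[C@H](O)[C@H]2O)nn1` gives 880 nM in this assay, and the step of an at least 1.1-fold lower number from compound 1 to compound 3 (0.05 log units; that floor lies within the scatter) is read against the same limit.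

Compound 4 `O=C1c2c[n+]([O-])c3ccccc3c2C(=O)c2c1c1ccccc1n2Cc1cn(C[C@@H](O)CO)nn1` differs from compound 1 as follows: the two compounds have the same atoms and bonds and differ only in configuration as drawn: 1 of 1 stereo elements differ; a stereocentre at a saturated chain carbon is drawn S in compound 1 and R in compound 4. Among the measured compounds shown here, no measured step touches the configuration at this carbon; the two measured steps concern replacement of the whole group or of the substituent on the triazole nitrogen, and both start from a limit. With only a limit for compound 1 and no measured effect of configuration, the expectation for compound 4 in this assay is a number near that limit, with the change a step that the limit leaves unreadable from compound 1 to compound 4 expected to stay within the scatter. Compound 4 is estimated at 2000 nM, between 800 nM and 6000 nM, and this assay is expected quite possibly to return only a limit again.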

Compound 4, half-maximal inhibitory concentration: > 500 nM
Compound 4: a limit, no number; the forecaster's own chance of this, stated with the estimate: 65%; the middle value does not contradict the limit.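

In this assay compound 4 gives > 500 nM, which is a limit and not a number. Among the compounds shown here, no step linking compound 4 to compound 1, compound 2 or compound 3 can be read. The compounds shown leave open whether the S or R configuration at the saturated chain carbon changes the value in this assay at all.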